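Aryl Ring Variation: Expectation for Compound 4

The source may report more compounds than this note shows. Statements on the series, on what has been measured and on what is new or still open speak of the compounds shown alone.

Compound 2 `COC1=C(C)C(=O)/C(=C(O)/C=C/c2ccc(OC)cc2)C(=O)C1(C)C` carries the 4-methoxyphenyl group on the shared core. Among the compounds with values here, in a functional assay on KB cells (Homo sapiens) for cytotoxicity (on this read-out higher numbers stand for an effect only at larger amounts of compound and lower numbers for an effect already at smaller amounts), compound 2 gives 2.9 ug/mL, the highest of the three numbers so far, but its two companions stand within the scatter of it: compound 3 `COC1=C(C)C(=O)/C(=C(O)/C=C/c2cccc(OC)c2)C(=O)C1(C)C` gives 2.4 ug/mL, and compound 1 `COC1=C(C)C(=O)/C(=C(O)/C=C/c2ccc(Br)cc2)C(=O)C1(C)C` gives 1.9 ug/mL. The steps between these three, a 1.5-fold higher number from compound 1 to compound 2 (0.18 log units; within the scatter), a 1.2-fold lower number from compound 2 to compound 3 (0.08 log units; within the scatter) and a 1.3-fold higher number from compound 1 to compound 3 (0.10 log units; within the scatter), are all within the scatter, so the aryl substituent pattern explored so far has left the read-out essentially flat.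

Compound 4 `COC1=C(C)C(=O)/C(=C(O)/C=C/c2ccccc2C)C(=O)C1(C)C` differs from compound 2 by 2-methylphenyl in place of 4-methoxyphenyl on a double-bonded chain carbon bound to a double-bonded chain carbon. Within the data shown here, no measured step removes the single acceptor of the aryl group or introduces a methyl there, so the bearing of the earlier steps is indirect. The closest evidence is the exchange of bromo for methoxy and the step from 4-methoxyphenyl to 3-methoxyphenyl, both within the scatter, which suggests the aryl portion tolerates variation without a step beyond the scatter.

Compound 4 is therefore expected to give 2.6 ug/mL in this assay, with a range of 1.2 ug/mL to 5.5 ug/mL; the step this implies, a 1.1-fold lower number from compound 2 to compound 4 (0.05 log units; within the scatter), is expected to lie within the scatter.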

Compound 4, concentration for half-maximal effect: 1.6 ug/mL
For compound 4 the middle estimate is 1.6-fold (0.21 log units) above the measured one; the range from low to high includes it.
By their numbers in this assay, from the lowest: compounds 4, 1, 3 and 2 (each within the scatter of the next).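

In this assay the steps of a 1.8-fold lower number from compound 2 to compound 4 (0.26 log units; within the scatter) and a 1.5-fold lower number from compound 3 to compound 4 (0.18 log units; within the scatter) and a 1.2-fold lower number from compound 1 to compound 4 (0.07 log units; within the scatter) all lie within the scatter, so 2-methylphenyl on a double-bonded chain carbon bound to a double-bonded chain carbon fits the flat picture set by the bromo and methoxy groups. Within the data shown here, what the earlier compounds did not show is that this holds for an entering group with 0 hydrogen-bond acceptors and 7 carbon atoms only: every aryl group before it carried either bromo or methoxy, and compound 4 has neither. Nothing at hand bears on why the read-out stays flat across these four aryl groups.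

The step from 4-methoxyphenyl to 2-methylphenyl changes the substituent and its place on the ring at once, so neither change can be read alone. From the compounds shown here alone, it remains open whether the flat picture survives a more different group at this chain carbon, such as an aminophenyl, a phenyl bearing a carboxylic acid, or a longer alkyl chain in place of the aryl ring.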